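A few compounds are considered here, and "the series" means these few. Any claim that something is new, unique, unknown or untested is made for them only; others in the source may bear on it.

Working notes on the series. Compound 2 `COc1ccc(C(=O)/C=C/c2cc3cc(C)ccc3nc2Cl)cc1` is one of two compounds with numbers in an assay on membranes from cerebellum for displacement of a labelled ligand from metabotropic glutamate receptor 1 (Rattus norvegicus), read by scintillation counting, with a stated time of 16 h; on this read-out higher numbers stand for weaker inhibition and lower numbers for stronger inhibition; the other is compound 1 `O=C(c1ccc(Cl)cc1)c1ccc2c(c1)CCCCO2`. In this assay compound 2 gives > 40000 nM, which is a limit of the assay and not a number. In this assay compound 1 also gives > 40000 nM, again a limit. Within the data shown here, both values sit at the limit of > 40000 nM in this assay, at which 2 of the 2 values shown sit, so compound 2 stands at the weak end of what this read-out can report, and no measured step between compounds exists to compare against.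

Compound 3 `Cc1ccc2nc(Cl)c(/C=C/C(=O)c3ccccc3)cc2c1` has not yet been measured. The change from compound 2 to compound 3 is hydrogen in place of methoxy on an aromatic carbon, para to a large group; cut one bond further out it reads 4-methoxyphenyl to phenyl. Among the measured compounds shown here, with no measured step available, the expectation in this assay is a step of no size beyond the scatter, in no particular direction, because compound 2 already sits at the limit of > 40000 nM in this assay, at which 2 of the 2 values shown sit. The expected step is a step that the limit leaves unreadable from compound 2 to compound 3. The estimate for compound 3 in this assay is 60000 nM, within 20000 nM to 200000 nM, and most likely the assay again reports only a limit.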

Compound 3, inhibition constant: 9180 nM
Compound 3: the middle estimate sits 6.5-fold (0.82 log units) above what was measured, outside the stated range (below it).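

In this assay, among these compounds, hydrogen in place of methoxy on an aromatic carbon, para to a large group, gives an at least 4.3-fold lower number from compound 2 to compound 3 (0.63 log units; beyond the scatter), which is the first readable effect of any change. Until now both compounds sat at the weak end of the read-out, so nothing showed that this position could affect the result; with 4-methoxyphenyl changed to phenyl, compound 3 gives 9180 nM, a number rather than a limit, and that value is a reference point for further changes at this position. The step has only a lower bound and its full size cannot be read, because compound 2 stands at a limit: the limit of > 40000 nM in this assay, at which 2 of the 3 values shown sit.

The compounds shown leave open whether any other group at this position, such as a fluorine, a hydroxyl or an amine, would give a number close to that of compound 3 or return to the limit. They also leave open whether a longer chain in place of the methoxy would behave like the methoxy, and this single step sets no trend for the position.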